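A few compounds are considered here, and "the series" means these few. Any claim that something is new, unique, unknown or untested is made for them only; others in the source may bear on it.

Measured compounds:
- compound 1, `Nc1ccccc1NC(=O)c1ccc(CNC2=N[C@H](Cc3ccccc3)CS2)cc1`: 12700 nM
- compound 2, `Nc1cc(C(=O)OCc2ccccc2)ccc1NC(=O)c1ccc(CNc2nccc(-c3cccnc3)n2)cc1`: a limit, > 20000 nM
- compound 3, `Nc1ccccc1NC(=O)c1ccc(CNC2=NC[C@@H](c3ccccc3)S2)cc1`: 1400 nM

In an assay for inhibition of histone deacetylase 8 (Homo sapiens), read by fluorescence, with stated times of 15 min and 60 min (on this read-out lower numbers stand for stronger inhibition and higher numbers for weaker inhibition), compound 1 gives 12700 nM, the highest of the two numbers obtained. Compound 3, the nearest, gives 1400 nM, a gap beyond the scatter. For compound 2 only a limit is recorded, > 20000 nM; the value of the limit of > 20000 nM in this assay, at which 1 of the 3 values shown sits, is a limit and not a number.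

The step under consideration leads from compound 1 to compound 4, `Nc1ccccc1NC(=O)c1ccc(CNC2=N[C@@H](Cc3ccccc3)CS2)cc1`. (the two compounds have the same atoms and bonds and differ only in configuration as drawn: 1 of 1 stereo elements differ; a stereocentre at a saturated ring carbon is drawn R in compound 1 and S in compound 4). Among the measured compounds shown here, no measured pair in the set differs in the same way, so no comparison step is available for sizing the effect; the only two numbers show that changing where the ring carries its substituent moved the result well beyond the scatter.

In the absence of a measured precedent the direction is open. Inversion at a single stereocentre can leave the number within the scatter or shift it by a large step either way; the plain expectation is a shift of modest size, with wide uncertainty in both directions, so compound 4 is expected to show a step of a 1.8-fold lower number from compound 1 to compound 4 (0.26 log units; within the scatter) from compound 1. Compound 4 is estimated at 7000 nM, with a range from 1500 nM to 25000 nM.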

Compound 4, half-maximal inhibitory concentration: 34900 nM
Compound 4: middle estimate off by 5.0-fold (0.70 log units), on the low side; measured number outside the range, above it.
By their numbers in this assay, from the lowest: compound 3; then compound 1; then compound 4.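

Drawing the stereocentre at the saturated ring carbon as S rather than R in this assay gives a 2.7-fold higher number from compound 1 to compound 4 (0.44 log units; beyond the scatter), the first step in the series that can be read at a single place. Among the compounds shown here, until now no pair differed in one place, so the sensitivity of this position to configuration alone had no size; it now has a modest one, beyond the scatter, and the R drawing gives the lower number of the two. The step can be assigned to that stereocentre alone, with no other change in the structure to share it, because of one fact: the fact that compounds 1 and 4 differ only in the configuration as drawn

On these data alone, whether the same order of the two configurations holds when an amine or a carboxylic acid is placed on the substituent at this stereocentre, or when a longer chain links that substituent to the ring, stays open. Also open, as far as these compounds go, is how inversion acts at the stereocentre of compound 3, and whether a step of similar size would appear there.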